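Furanoyl thioxo-piperazine series: enaminonitrile amide to ketone

The compounds below may be only part of what the source reports. "The series", "measured", "known", "first", "only" and "open" are said of these compounds alone.

Of the compounds shown here, three of a shared core have been measured in a functional assay on MDA-MB-231 cells (Homo sapiens) for inhibition, read by sulforhodamine B assay, with a stated time of 48 h; on this read-out higher numbers stand for weaker inhibition of growth and lower numbers for stronger inhibition of growth. Compound 1 `N#C/C(=C\N1CCN(C(=O)c2ccco2)C1=S)C(N)=O` gives 13100 nM in this assay. Compound 2 `O=CN1CCN(C(=O)c2ccco2)C1=S` gives 15900 nM in this assay, and compound 3 `O=CN1CCN(c2cc(Cl)cc(Cl)c2)C1=S` gives 15600 nM in this assay. Compound 1 carries the lowest of the three numbers, but its gaps to compound 2 and to compound 3 both lie within the scatter of repeated measurements, so the three values are read as indistinguishable. For the measured compounds named here, no pair among the measured compounds differs in only one place, so no single-point step has been measured in this assay.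

Compound 4 `N#C/C(=C\N1CCN(C(=O)c2ccco2)C1=S)C(=O)c1ccccc1` is not yet measured. It differs from compound 1 in one place: phenyl in place of amino on a carbonyl carbon. Going by the values given here, with no measured step of this kind available, the expectation rests on the value of compound 1 alone; the step from compound 1 to compound 4 is expected to be small, a 1.3-fold lower number from compound 1 to compound 4 (0.12 log units; within the scatter), with no confident direction beyond the scatter. For compound 4 the estimate in this assay is 10000 nM, expected within 3000 nM to 35000 nM.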

Compound 4, concentration for 50% growth inhibition: 13700 nM
Compound 4: the middle estimate sits 1.4-fold (0.14 log units) below what was measured; low and high end bracket the measured number.
By their numbers in this assay, from the lowest: compounds 1, 4, 3 and 2 (each within the scatter of the next).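

In this assay the exchange of amino for phenyl on a carbonyl carbon reads as a 1.0-fold higher number from compound 1 to compound 4 (0.02 log units; within the scatter) and gives the series its first single-place step. At this position, then, a six-membered aromatic ring of carbon only can stand where amino stood, and the loss of the amino hydrogen-bond donor comes with no readable difference in growth inhibition. Nothing at hand offers a reason for this flat result or shows whether the two groups act alike in the cells.

Still open, from the compounds shown here alone, is whether any group on this carbonyl carbon moves the number beyond the scatter, for instance a hydroxyl as in the carboxylic acid, a dimethylamino group or a methyl. Also open, going by these compounds, is whether a chloro-substituted phenyl on the ketone would read any differently from the plain phenyl of compound 4.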